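The compounds below may be only part of what the source reports. "The series", "measured", "known", "first", "only" and "open" are said of these compounds alone.

Compound 1 `O=C(O)c1ccccc1-c1ccc(CCc2ncc(Cc3cccc(Cl)c3)[nH]2)cc1` gives 825 nM in an in vitro functional assay on cells for agonist activity at Bombesin receptor subtype-3 (Homo sapiens), read by luminescence and calcium flux; a lower number here means that less compound is needed, a higher number that more compound is needed for the effect.
Compound 2 `N#Cc1ccccc1Cc1cnc(CCc2ccc(-c3ccccc3C(=O)O)cc2)[nH]1` gives 5480 nM in this assay.
Compound 3 `N#Cc1cccc(Cc2cnc(CCc3ccc(-c4ccccc4C(=O)O)cc3)[nH]2)c1` gives 812 nM in this assay.

Among these three numbers compound 1 stands second highest, although compound 3 sits within the scatter of it, a 1.0-fold lower number from compound 1 to compound 3 (0.01 log units; within the scatter), while compound 2 lies further off, a 6.6-fold higher number from compound 1 to compound 2 (0.82 log units; beyond the scatter). Compound 4 `O=C(O)c1ccccc1-c1ccc(CCc2ncc(Cc3cccc(F)c3)[nH]2)cc1` differs from compound 1 by fluoro in place of chloro on an aromatic carbon. For the measured compounds named here, the step that bears most directly on this change is the one swapping the group on that aromatic carbon, a 1.0-fold lower number from compound 1 to compound 3 (0.01 log units; within the scatter), which stayed within the scatter. The other two steps, a 6.6-fold higher number from compound 1 to compound 2 (0.82 log units; beyond the scatter) and a 6.7-fold lower number from compound 2 to compound 3 (0.83 log units; beyond the scatter), were modest and concern where the group sits rather than which group it is. A step no larger than the scatter is therefore expected, a 1.5-fold higher number from compound 1 to compound 4 (0.16 log units; within the scatter). Compound 4 is estimated at 1200 nM, within 500 nM to 3000 nM.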

Compound 4, half-maximal effective concentration: 159 nM
Compound 4: middle estimate off by 7.5-fold (0.88 log units), on the high side, outside the stated range (below it).
By their numbers in this assay, from the lowest: compound 4; then compounds 3 and 1 (each within the scatter of the next); then compound 2.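

Chloro and cyano on this aromatic carbon had given matching numbers, which made the choice of group look unimportant, but fluoro breaks that picture, with a 5.2-fold lower number from compound 1 to compound 4 (0.72 log units; beyond the scatter) and a 5.1-fold lower number from compound 3 to compound 4 (0.71 log units; beyond the scatter). The group at this position therefore does matter, and a 34-fold lower number from compound 2 to compound 4 (1.54 log units; beyond the scatter) is the largest step among the four compounds. Nothing available explains why fluoro stands apart from chloro and cyano.

As far as these compounds go, what a methyl, a methoxy or a plain hydrogen on that carbon would give remains open. So does whether fluoro would keep this advantage elsewhere on the ring.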